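A Smaller Polar Group on the Saturated Ring

A few compounds are considered here, and "the series" means these few. Any claim that something is new, unique, unknown or untested is made for them only; others in the source may bear on it.

Of the compounds shown here, two have been measured so far. Compound 1 `CCCN(C)c1ncnc2[nH]cc(-c3cccc(Cl)c3)c12` is one of them; in an assay for inhibition of serine/threonine-protein kinase 4 (Homo sapiens), read by luminescence and ADP-Glo, in the presence of a further agent that is not named here (on this read-out higher numbers stand for weaker inhibition and lower numbers for stronger inhibition), compound 1 gives 208 nM. Compound 2 `CC(=O)NC1CCN(c2ncnc3[nH]cc(-c4cccc(Cl)c4)c23)CC1` is the other; in this assay compound 2 gives 26 nM, the lower of the two numbers and therefore the stronger inhibitor, with compound 1 standing well beyond the usual scatter above it. Compound 3 `OC1CCN(c2ncnc3[nH]cc(-c4cccc(Cl)c4)c23)CC1` has not been measured yet. It differs from compound 2 by hydroxy in place of acetamido on a saturated ring carbon. For the measured compounds named here, no measured pair shows what such a swap does on this core, so the expectation rests only on the fact that compound 2 already sits at the low end of the numbers seen. Compound 3 is expected to come out somewhat weaker than compound 2, though a result within the scatter would not be surprising; the expected step is a 2.7-fold higher number from compound 2 to compound 3 (0.43 log units; beyond the scatter). For compound 3 in this assay the estimate is 70 nM, with a range from 25 nM to 250 nM.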

Compound 3, half-maximal inhibitory concentration: 80 nM
Compound 3: the middle estimate sits 1.1-fold (0.06 log units) below what was measured; the measured number falls inside the stated range.
By their numbers in this assay, from the lowest: compound 2; then compound 3; then compound 1.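

In this assay, putting hydroxy in place of acetamido on the saturated ring carbon takes the group from four heavy atoms to one while the count of one hydrogen-bond donor and one acceptor stays the same, and this change gives a 3.1-fold higher number from compound 2 to compound 3 (0.49 log units; beyond the scatter) at this position. So the two groups are not interchangeable here, and of the two, acetamido goes with the stronger inhibition. Hydroxy on the ring still does better than the open chain, since 4-hydroxypiperidin-1-yl in place of methyl(propyl)amino on an aromatic carbon gives a 2.6-fold lower number from compound 1 to compound 3 (0.41 log units; beyond the scatter) on the same core, but nothing in the available data explains the size of either step.

The swap from acetamido to hydroxy removes the carbonyl, the methyl and the amide nitrogen all at once, so these compounds cannot show which of those parts goes with the lower number. A primary amine or a methoxy group on the same ring carbon, or a longer amide such as propanamido, would help separate these parts, and a plain hydrogen there would show what the ring does with no group on that carbon at all.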